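Methylsulfanyl in place of iodo: notes on cytotoxicity

The source may report more compounds than this note shows. Statements on the series, on what has been measured and on what is new or still open speak of the compounds shown alone.

Among the compounds with values here, in an ADME assay on Vero 76 cells (Chlorocebus sabaeus) for cytotoxicity, read by microscopy (on this read-out higher numbers stand for lower toxicity in this test and lower numbers for higher toxicity in this test), compound 1 (`CC(C)[C@@H](Nc1nc(I)nc2c1ncn2[C@H]1[C@H](O)[C@H](O)[C@]2(CO)C[C@H]12)C1CC1`) gives 100000 nM as the only plain number so far. Compound 2 (`CC(C)(O)[C@@H](Nc1nc(Cl)nc2c1ncn2[C@H]1[C@H](O)[C@H](O)[C@]2(CO)C[C@H]12)C1CC1`) reads > 100000 nM and that is a limit of the assay, not a number. Within the data shown here, no measured pair isolates a single change, so no step size can be carried over.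

Compound 3 (`CSc1nc(N[C@H](C(C)C)C2CC2)c2ncn([C@H]3[C@H](O)[C@H](O)[C@]4(CO)C[C@H]34)c2n1`) carries methylsulfanyl in place of iodo on an aromatic carbon between two ring nitrogen atoms (methylsulfanyl in place of iodo on an aromatic carbon). With compound 1 at 100000 nM as the reference, no step beyond the usual scatter is expected in this assay in either direction. A reading at the limit of the assay is a real possibility for compound 3. The estimated change is small (a 1.1-fold lower number from compound 1 to compound 3 (0.05 log units; within the scatter)). For compound 3 the expected half-maximal cytotoxic concentration is 90000 nM within an estimated range of 40000 nM to 150000 nM in this measurement.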

Compound 3, half-maximal cytotoxic concentration: > 100000 nM
Compound 3 ended at the assay's limit; the forecaster's own chance of this, stated with the estimate: 55%; at least 1.1-fold (0.04 log units) between middle value and limit.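

The step in this assay reads a number no lower from compound 1 to compound 3 (the limit leaves the size open) and its size cannot be read. Compound 3 gives > 100000 nM as a limit of the assay and not a number. This is the first change in the series isolated in one place, and on an aromatic carbon between two ring nitrogen atoms methylsulfanyl in place of iodo brings no lower number, with most of the series now sitting at one limit: the limit of > 100000 nM in this assay, at which 2 of the 3 values shown sit.

On these data alone, how far compound 3 lies from compound 1 stays open. Also open, as far as these compounds go, is whether an amine or a carboxylic acid on this same carbon would keep the number clear of a drop in this test.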